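Swapping one hydroxyphenyl group for another in compound 4

The source may report more compounds than this note shows. Statements on the series, on what has been measured and on what is new or still open speak of the compounds shown alone.

Compound 1 (`O=C(N/N=C/c1ccco1)c1cccc(S(=O)(=O)N2CCOCC2)c1`) gives > 100000 nM (a limit of the assay, not a number)
Compound 2 (`COc1ccc(/C=N/NC(=O)c2cccc(S(=O)(=O)N3CCOCC3)c2)c(O)c1`) gives 2790 nM
Compound 3 (`CCOc1cccc(/C=N/NC(=O)c2cccc(S(=O)(=O)N3CCOCC3)c2)c1O`) gives 16500 nM

All three values come from a functional assay on ECa-109 cells for antiproliferative activity against ECa-109 cell line (Homo sapiens), read by MTT assay, with a stated time of 72 h (a higher number here means a weaker inhibitor, a lower number a stronger inhibitor), and share one core. Compound 3 at 16500 nM holds the higher of the two actual numbers, and its nearest neighbour is compound 2.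

Compound 4 (`O=C(N/N=C/c1cc(Br)ccc1O)c1cccc(S(=O)(=O)N2CCOCC2)c1`) differs from compound 3 in one group (5-bromo-2-hydroxyphenyl in place of 3-ethoxy-2-hydroxyphenyl on a carbon with a double bond to nitrogen), on a carbon with a double bond to nitrogen. The closest guide is the exchange of one hydroxyphenyl group for another, a modest change (a 5.9-fold higher number from compound 2 to compound 3 (0.77 log units; beyond the scatter)). Two larger steps (an at least 35-fold lower number from compound 1 to compound 2 (1.55 log units; beyond the scatter)) and (an at least 6.0-fold lower number from compound 1 to compound 3 (0.78 log units; beyond the scatter)) replaced furan-2-yl, but compound 4 keeps a hydroxyphenyl group, so a change of that size is not expected here.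

Within the data shown here, no compound carrying bromine has been measured, so the direction is uncertain. With compound 3 at 16500 nM already the higher of the pair, a modest move down seems likelier than a further rise. The expected step is a 2.8-fold lower number from compound 3 to compound 4 (0.44 log units; beyond the scatter) and remains a rough estimate. The estimated value for compound 4 is 6000 nM (expected range 1500 nM to 25000 nM).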

Compound 4, half-maximal inhibitory concentration: 11700 nM
Beside the measured number, compound 4's estimate is 2.0-fold (0.29 log units) below it, and the stated range covers the measured number.
By their numbers in this assay, from the lowest: compound 2; then compounds 4 and 3 (each within the scatter of the next). At a limit, above all of these: compound 1.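

In this assay, the 5-bromo-2-hydroxyphenyl and 3-ethoxy-2-hydroxyphenyl groups cannot be told apart on a carbon with a double bond to nitrogen (a 1.4-fold lower number from compound 3 to compound 4 (0.15 log units; within the scatter)), even though the two groups carry different substituents. The 2-hydroxy-4-methoxyphenyl group of compound 2 stays clearly ahead of this new group too (a 4.2-fold higher number from compound 2 to compound 4 (0.62 log units; beyond the scatter)), so among the three hydroxyphenyl groups shown, only compound 2 stands apart. A third hydroxyphenyl group also improves on the furan-2-yl group (an at least 8.5-fold lower number from compound 1 to compound 4 (0.93 log units; beyond the scatter)), though this step is only a bound, as the value of compound 1 is a limit and not a number: the limit of > 100000 nM in this assay, at which 1 of the 4 values shown sits.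

The compounds shown cannot separate the contribution of the hydroxyl from that of the other substituents, as every hydroxyphenyl group here keeps a hydroxyl and the three differ in what else they carry. On these data alone, it also remains open how an amine, a carboxylic acid or a longer chain in place of the bromine would behave in this assay and whether any of them would approach compound 2.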